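The compounds below may be only part of what the source reports. "The series", "measured", "known", "first", "only" and "open" are said of these compounds alone.

Compound 1 `NC(=O)c1c(NC(=O)c2ccc(C(F)(F)F)cc2)sc2c1CCN(Cc1c(Cl)cccc1Cl)C2`: in a functional assay on HeLa cells (Homo sapiens) for antiproliferative activity, with a stated time of 24 h (on this read-out higher numbers stand for weaker inhibition and lower numbers for stronger inhibition), compound 1 gives > 50000 nM, which is a limit of the assay rather than a number.
Compound 2 `Cc1ccc(C(=O)Nc2sc3c(c2C(N)=O)CCN(Cc2c(Cl)cccc2Cl)C3)cc1`: in this assay compound 2 gives 47400 nM.
Compound 3 `NC(=O)c1c(NC(=O)c2ccccc2C(F)(F)F)sc2c1CCN(C(=S)Nc1ccccc1Cl)C2`: in this assay compound 3 gives 46900 nM.

Compound 1 and compound 2 share a core and differ only in one group, (methyl in place of trifluoromethyl on an aromatic carbon). The step between them in this assay is an at least 1.0-fold lower number from compound 1 to compound 2 (0.02 log units; that floor lies within the scatter); it rests on (the limit of > 50000 nM in this assay, at which 1 of the 3 values shown sits), so its true size is open. The values of compound 2 and compound 3 lie within the scatter of each other, so nothing can be said about their order. The difference between the core of compound 3 and the core of compound 1 is not broken down here.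

Compound 4 `Cc1ccccc1C(=O)Nc1sc2c(c1C(N)=O)CCN(C(=S)Nc1ccccc1Cl)C2` is not yet measured. It differs from compound 3 by methyl in place of trifluoromethyl on an aromatic carbon. Within the data shown here, this is the same kind of change as the one from compound 1 to compound 2, but the place is not identical: in the earlier pair the group sits para to a large group, in the present pair it sits ortho to a large group. Given the earlier step, which showed no clear movement, the expected step in this assay is a 1.0-fold lower number from compound 3 to compound 4 (0.02 log units; within the scatter). On that basis compound 4 is estimated to give 45000 nM in this assay, within a range from 20000 nM to 100000 nM, with a fair chance that only a limit is reported.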

Compound 4, half-maximal inhibitory concentration: 35300 nM
Estimate against measurement, compound 4: 1.3-fold (0.11 log units) above; the range from low to high includes it.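

In this assay, methyl in place of trifluoromethyl on an aromatic carbon, here the change from 2-(trifluoromethyl)phenyl to 2-methylphenyl, gives a 1.3-fold lower number from compound 3 to compound 4 (0.12 log units; within the scatter). Set beside the earlier step on the other core, the change has now been seen on two cores without a step that stands clear of the scatter, and it cannot be decided whether the two steps differ: the same change on two cores in this assay, an at least 1.0-fold lower number (0.02 log units; that floor lies within the scatter) from compound 1 to compound 2 and a 1.3-fold lower number (0.12 log units; within the scatter) from compound 3 to compound 4; the limit leaves it open whether they differ. Among these compounds, this shows only that neither core gave a clear movement for this change; it does not show that the change carries over with a fixed size, as the place on the ring is not the same in the two pairs and one step rests on a limit: the limit of > 50000 nM in this assay, at which 1 of the 4 values shown sits.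

The compounds shown leave open whether a different group on that aromatic carbon, such as a methoxy group or an amine, would move the number beyond the scatter on either core. They also leave open what a nitrile or a carboxylic acid in place of the carboxamide would do, and how the two cores compare when they carry the same aromatic group in the same place.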